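A few compounds are considered here, and "the series" means these few. Any claim that something is new, unique, unknown or untested is made for them only; others in the source may bear on it.

Two compounds share one core. Compound 1 `Nc1ccccc1NC(=O)c1ccc(CSC(=S)N2CCN(c3ccccc3)CC2)cc1` carries a phenyl on the amine nitrogen of its six-membered non-aromatic ring, and in a functional assay on A-375 cells (Homo sapiens) for antiproliferative activity, read by CCK-8 assay, with a stated time of 72 h, tested at 8 uM (a higher number here means a stronger effect of the compound at the concentration tested, a lower number a weaker effect), compound 1 gives 88.6%. Compound 2 `Nc1ccccc1NC(=O)c1ccc(CSC(=S)N2CCN(c3ncccn3)CC2)cc1` differs only in bearing pyrimidin-2-yl at that place, and in this assay compound 2 gives 67.9%. Within the data shown here, that is the lower of the two numbers known so far, and the one measured step, a number 20.7 percentage points lower from compound 1 to compound 2 (beyond the scatter), is all that connects them.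

The next compound is compound 3 `Nc1ccccc1NC(=O)c1ccc(CSC(=S)N2CCN(c3ccccc3F)CC2)cc1`. The change from compound 2 is this: 2-fluorophenyl in place of pyrimidin-2-yl on an amine nitrogen in a ring. Among the measured compounds shown here, the only measured step that bears on it is a number 20.7 percentage points lower from compound 1 to compound 2 (beyond the scatter), since the entering 2-fluorophenyl is, like the phenyl of compound 1, a six-membered aromatic ring of carbon only, here carrying fluorine. Much of that loss is therefore expected to be recovered, and a step of about a number 14.1 percentage points higher from compound 2 to compound 3 (beyond the scatter) is estimated. For compound 3 in this assay the expected value is 82%, with a range from 66% to 94%.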

Compound 3, a percentage reported as inhibition, at one concentration (the size of the read-out at that concentration, not a potency): 79.5%
Estimate against measurement, compound 3: 2.5 percentage points above, and the stated range covers the measured number.
By their numbers in this assay, from the lowest: compound 2; then compounds 3 and 1 (each within the scatter of the next).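

In this assay the step of a number 11.6 percentage points higher from compound 2 to compound 3 (beyond the scatter) shows the same gap as the earlier step from a second direction: on the amine nitrogen in the ring, a pyrimidin-2-yl goes with a lower number than a second carbon-only aromatic ring, the 2-fluorophenyl, and not only than the plain phenyl. The step of a number 9.1 percentage points lower from compound 1 to compound 3 (within the scatter) adds that fluoro in place of hydrogen on an aromatic carbon gives no readable change, so compound 1 and compound 3 cannot be told apart here, while compound 2 stands lowest of the three, with its steps to both others beyond the scatter. Nothing available explains why the two-nitrogen ring differs from the carbon-only rings.

Still open, from the compounds shown here alone, is how a pyridin-2-yl, with one ring nitrogen, would fall between these groups, and whether a chloro or methoxy on the phenyl, or a saturated cyclohexyl at the same nitrogen, would also match compound 1. These numbers are also effects at a single concentration in one cell line, so they leave the potency of all three compounds unsettled.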